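The source may hold more compounds than are shown below. What is called first, only, known or untested is meant among the compounds shown, and "the series" means these compounds.

Measured in a functional assay on MDA-MB-435 cells (Homo sapiens) for inhibition; on this read-out lower numbers stand for stronger inhibition of growth and higher numbers for weaker inhibition of growth:

compound 1 `COc1cccc(/C=C/c2ccc(S(N)(=O)=O)cc2)c1`: 17400 nM
compound 2 `NS(=O)(=O)c1ccc(/C=C/c2ccc(F)cc2)cc1`: 27000 nM

Compound 2 and compound 1 lie within the usual scatter of each other, so neither can be set apart from the other on these two numbers. Compound 3 `NS(=O)(=O)c1ccc(/C=C/c2ccc(O)cc2)cc1` is not yet measured. It differs from compound 2 by hydroxy in place of fluoro on an aromatic carbon. For the measured compounds named here, no step between measured compounds bears on this change, so nothing here argues for a shift beyond the scatter in either direction. Compound 3 is therefore expected to come out near compound 2, with the step from a 1.4-fold lower number from compound 2 to compound 3 (0.13 log units; within the scatter) estimated as small; the estimate is 20000 nM, between 5000 nM and 60000 nM.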

Compound 3, concentration for 50% growth inhibition: 20300 nM
The estimate for compound 3 lay 1.0-fold (0.01 log units) below the measured number, within the range that was stated.
By their numbers in this assay, from the lowest: compounds 1, 3 and 2 (each within the scatter of the next).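

In this assay hydroxy in place of fluoro on an aromatic carbon, para to a large group, comes with a 1.3-fold lower number from compound 2 to compound 3 (0.12 log units; within the scatter) and so brings in a hydrogen-bond donor and a hydrogen-bond acceptor at this position without a shift beyond the scatter. For the compounds shown here, this is the first step read at this position, and fluoro and hydroxy cannot be told apart there on this read-out. No supporting data bear on this result.

Open, from the compounds shown here alone, is whether an amine, a carboxylic acid or a longer chain at this position would move the number beyond the scatter. Also open, going by these compounds, is whether any change to the sulfonamide would do so.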